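The source may report more compounds than this note shows. Statements on the series, on what has been measured and on what is new or still open speak of the compounds shown alone.

In a functional assay on A-375 cells (Homo sapiens) for antiproliferative activity (on this read-out lower numbers stand for stronger inhibition and higher numbers for weaker inhibition), compound 1 `O=C(Nc1ccc(-c2cscn2)cc1)C1CCCN(Cc2ccc(F)c(F)c2)C1` gives 880 nM and compound 2 `O=C(Nc1ccc(-c2cscn2)cc1)C1CCCN(Cc2cccc(F)c2F)C1` gives 1480 nM, so the two cannot be told apart. For compound 3 `O=C(Nc1ccc(-c2cscn2)cc1)C1CCCN(Cc2ccc3cn[nH]c3c2)C1`, the reported > 20000 nM is a limit of the assay. Compound 4 `O=C(Nc1ccc(-c2ccncc2)cc1)C1CCCN(Cc2ccc(F)c(F)c2)C1` keeps the core of compound 1 and changes one place: pyridin-4-yl in place of 1,3-thiazol-4-yl on an aromatic carbon. For the measured compounds named here, none of the measured steps touches that place. a 1.7-fold higher number from compound 1 to compound 2 (0.23 log units; within the scatter), while an at least 22-fold higher number from compound 1 to compound 3 (1.35 log units; beyond the scatter) and an at least 13-fold higher number from compound 2 to compound 3 (1.13 log units; beyond the scatter); all three concern the group on the amine nitrogen instead. They give no size or direction for this change, so no step beyond the scatter is firmly expected. The expected step is a 1.3-fold higher number from compound 1 to compound 4 (0.10 log units; within the scatter). The estimate for compound 4 in this assay is 1100 nM, with an expected range of 300 nM to 4500 nM.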

Compound 4, half-maximal inhibitory concentration: 600 nM
The estimate for compound 4 lay 1.8-fold (0.26 log units) above the measured number; low and high end bracket the measured number.
By their numbers in this assay, from the lowest: compounds 4, 1 and 2 (each within the scatter of the next, the first and the last beyond it). At a limit, above all of these: compound 3.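

For the compounds shown here, the exchange of 1,3-thiazol-4-yl for pyridin-4-yl gives a 1.5-fold lower number from compound 1 to compound 4 (0.17 log units; within the scatter) in this assay, the first reading at this place on the aromatic ring. For this one pair, a six-membered aromatic ring with 1 hetero atom stands in for the five-membered ring with 2 hetero atoms without a change that can be told from the scatter. The data shown offer no cause for this step. Still open, on these data alone, is whether a phenyl, a carboxylic acid or an aminomethyl group at this place would behave alike. Also open, as far as these compounds go, is whether pyridin-4-yl would give a similar step with the 2,3-difluorophenyl group of compound 2.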